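Compound 1 and a Hydroxymethylphenyl Variant in a Cell Assay

The source may hold more compounds than are shown below. What is called first, only, known or untested is meant among the compounds shown, and "the series" means these compounds.

Compound 1 `OC[C@H]1O[C@@H](n2cnc3c(NCc4ccc(F)cc4)ncnc32)[C@H](O)[C@@H]1O` carries a 4-fluorophenyl on a saturated chain carbon bound to a nitrogen on an aromatic ring. In a functional assay on HL-60 cells (Homo sapiens) for antiproliferative activity, with a stated time of 72 h (a lower number here means a stronger inhibitor, a higher number a weaker inhibitor), compound 1 gives 1200 nM, the lowest of the two numbers available. Compound 2 `OC[C@H]1O[C@@H](n2cnc3c(NCc4ccc(Cl)cc4Cl)ncnc32)[C@H](O)[C@@H]1O` gives 96300 nM, and the step from the first to the second is an 80-fold higher number from compound 1 to compound 2 (1.90 log units; beyond the scatter). Compound 3 `OC[C@H]1O[C@@H](n2cnc3c(NCc4cc(O)cc(O)c4)ncnc32)[C@H](O)[C@@H]1O` has "not determined" (no result reported) in this assay, so it adds nothing to the comparison.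

Compound 4 `Cc1ccc(O)c(CNc2ncnc3c2ncn3[C@@H]2O[C@H](CO)[C@@H](O)[C@H]2O)c1` differs from compound 1 by 2-hydroxy-5-methylphenyl in place of 4-fluorophenyl on a saturated chain carbon bound to a nitrogen on an aromatic ring. Among the measured compounds shown here, the only measured step at this position is an 80-fold higher number from compound 1 to compound 2 (1.90 log units; beyond the scatter), a large loss when the ring grew more heavily substituted with halogens. For the measured compounds named here, the change to compound 4 is of a different kind, bringing a hydrogen-bond donor and acceptor to the ring, and no measured pair shows its effect. The expectation is therefore a moderate loss, smaller than that of compound 2, with wide uncertainty. Compound 4 is expected at 5000 nM, between 800 nM and 30000 nM, which is an estimated step of a 4.2-fold higher number from compound 1 to compound 4 (0.62 log units; beyond the scatter).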

Compound 4, half-maximal inhibitory concentration: 15000 nM
Estimate against measurement, compound 4: 3.0-fold (0.48 log units) below, within the range that was stated.
By their numbers in this assay, from the lowest: compound 1; then compound 4; then compound 2.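

In this assay, the change to 2-hydroxy-5-methylphenyl gives a 13-fold higher number from compound 1 to compound 4 (1.10 log units; beyond the scatter), so a group without halogen also stands well above compound 1, and the loss is not confined to 2,4-dichlorophenyl. The same group gives a 6.4-fold lower number from compound 2 to compound 4 (0.81 log units; beyond the scatter), showing that the two replacements at this position are not equivalent, with a gap beyond the scatter. No evidence here bears on why these numbers differ.

The compounds shown leave open whether the hydroxy or the methyl of compound 4 accounts for its step, and whether any group at this position can reach a lower number than compound 1. An unsubstituted phenyl or a 4-aminophenyl would extend the comparison.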